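A Furan in Place of a Pyrazole on the Shared Core

The compounds below may be only part of what the source reports. "The series", "measured", "known", "first", "only" and "open" are said of these compounds alone.

Compound 1 `CCN(c1cccc(-c2ccccc2)c1)c1ccc(C#N)c(Cl)c1` carries a phenyl group on the shared core, and in a functional assay on VCaP cells (Homo sapiens) for antiproliferative activity, read by CCK-8 assay, with a stated time of 6 days (on this read-out higher numbers stand for weaker inhibition and lower numbers for stronger inhibition), compound 1 gives "not determined" (no result reported). Going by the values given here, compound 2 `CCN(c1ccc(C#N)c(Cl)c1)c1cc(-c2ccnn2C)ccc1C` is the one compound of the three with a definite number: in this assay compound 2 gives 1670 nM. Compound 3 `CCN(c1cccc(-c2cncnc2)c1)c1ccc(C#N)c(Cl)c1` reaches only a limit in this assay, giving > 30000 nM. That limit, (the limit of > 30000 nM in this assay, at which 1 of the 3 values shown sits), is as far as this assay reaches here, so the value for compound 3 stands as a limit and not as a number.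

Compound 4 `CCN(c1ccc(C#N)c(Cl)c1)c1cc(-c2ccoc2)ccc1C` differs from compound 2 in a single place: furan-3-yl in place of 1-methyl-1H-pyrazol-5-yl on an aromatic carbon. Among the compounds with values here, no step between two measured compounds connects this change, so the size of the step from compound 2 to compound 4 in this assay cannot be read from what is known; the account expects a step of about the usual scatter, leaning slightly toward weaker inhibition. Compound 4 is therefore estimated to give 2500 nM in this assay, within 800 nM to 8000 nM. The step this estimate means is expected to be a 1.5-fold higher number from compound 2 to compound 4 (0.18 log units; within the scatter).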

Compound 4, half-maximal inhibitory concentration: 4010 nM
Estimate against measurement, compound 4: 1.6-fold (0.21 log units) below, within the range that was stated.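

Replacing 1-methyl-1H-pyrazol-5-yl with furan-3-yl, one five-membered aromatic ring for another, gives in this assay a 2.4-fold higher number from compound 2 to compound 4 (0.38 log units; beyond the scatter), so this exchange registers on the read-out. The earlier compounds shown here offered no step at all, which makes this the first sign that the choice of ring on this aromatic carbon, para to a methyl group, matters, with the stronger inhibition lying on the side of the pyrazole. No measured property shown here bears on this step.

The compounds shown leave open how an amine, a carboxylic acid or a longer chain would read at this place. They also leave open whether the same exchange gives a step of like size on a core without the methyl group.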